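Terminal phenyl substituent removed: compound 4 expectation

A few compounds are considered here, and "the series" means these few. Any claim that something is new, unique, unknown or untested is made for them only; others in the source may bear on it.

Measured so far:
compound 1, `CCCc1cc(N)c2cc(NC(=O)/C=C/c3ccc(C(C)C)cc3)ccc2n1`, gives 2.9 nM in an assay on isolated protein for displacement of a labelled ligand from melanin-concentrating hormone receptor 1 (Homo sapiens); a higher number here means a weaker inhibitor, a lower number a stronger inhibitor
compound 2, `CCCCc1ccc(/C=C/C(=O)Nc2ccc3nc(CCC)cc(N)c3c2)cc1`, gives 45 nM
compound 3, `CCCc1cc(N)c2cc(NC(=O)/C=C/c3ccc(SC)cc3)ccc2n1`, gives 9 nM

Compound 3 stands second highest of the three numbers: a 3.1-fold higher number from compound 1 to compound 3 (0.49 log units; beyond the scatter), while a 5.0-fold lower number from compound 2 to compound 3 (0.70 log units; beyond the scatter). All three steps are beyond the scatter, so the group on this aromatic carbon clearly moves the number.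

Compound 4, `CCCc1cc(N)c2cc(NC(=O)/C=C/c3ccccc3)ccc2n1`, is not yet measured in this assay. The change from compound 3 is hydrogen in place of methylsulfanyl on an aromatic carbon. Within the data shown here, no measured step removes the group at this position altogether; each exchanges one group for another. Of those, a 16-fold higher number from compound 1 to compound 2 (1.19 log units; beyond the scatter) was large, and a 3.1-fold higher number from compound 1 to compound 3 (0.49 log units; beyond the scatter) and a 5.0-fold lower number from compound 2 to compound 3 (0.70 log units; beyond the scatter) were modest. The three measured groups span a wide range at this site, so a bare phenyl is unlikely to land within the scatter of compound 3, and the direction of exchange so far points to a weaker number when the group is changed away from isopropyl. A modest rise is therefore expected, a 3.3-fold higher number from compound 3 to compound 4 (0.52 log units; beyond the scatter). Compound 4 is estimated at 30 nM, with a range from 8 nM to 120 nM; the absence of any measured removal of the group keeps this range wide.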

Compound 4, half-maximal inhibitory concentration: 1000 nM
Compound 4: the middle estimate sits 33-fold (1.52 log units) below what was measured, outside the stated range (above it).
By their numbers in this assay, from the lowest: compound 1; then compound 3; then compound 2; then compound 4.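

In this assay the bare phenyl of compound 4 falls far behind every substituted analogue: a 110-fold higher number from compound 3 to compound 4 (2.05 log units; beyond the scatter), a 22-fold higher number from compound 2 to compound 4 (1.35 log units; beyond the scatter) and a 340-fold higher number from compound 1 to compound 4 (2.54 log units; beyond the scatter), all large and all beyond the scatter. The earlier steps only exchanged one group for another, whereas these show that, among the compounds here, any of the three groups on this aromatic carbon gives a much lower number than hydrogen, with no compound going against this; even methylsulfanyl, with only 2 heavy atoms, accounts for a larger step than any exchange among isopropyl, butyl and methylsulfanyl. Nothing in the data at hand explains the size of these steps.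

On these data alone, how small a group can be and still keep most of the low number remains open, for instance a single fluorine or chlorine atom, a methyl or a methoxy in place of methylsulfanyl. Also open, as far as these compounds go, is how an amine or a carboxylic acid would fare on this carbon, and whether branching or chain length separates isopropyl from butyl, which a propyl or a tert-butyl would help to show.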